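The source may hold more compounds than are shown below. What is called first, only, known or untested is meant among the compounds shown, and "the series" means these compounds.

Working notes on the series. Compound 1 `CCC1(COC(=O)Nc2ccc(F)cc2)OC(=O)Nc2ccc(Cl)cc21` gives 2260 nM in an assay for inhibition of very long chain fatty acid elongase 6 (Homo sapiens); a higher number here means a weaker inhibitor, a lower number a stronger inhibitor. For the measured compounds named here, compound 2 `CC(C)C1(COC(=O)Nc2ccc(F)cc2)OC(=O)Nc2ccc(Cl)cc21` gives 5030 nM in this assay; the single change between the two is captured by a 2.2-fold higher number from compound 1 to compound 2 (0.35 log units; beyond the scatter), the only step in the set so far. Compound 3 `O=C1Nc2ccc(Cl)cc2C(CNC(=O)c2cccc(F)c2)(C(F)(F)F)O1` gives 261 nM in this assay, the lowest of the three numbers, with compound 1 nearest and compound 2 furthest, both separations beyond the scatter.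

Compound 4 `O=C1Nc2ccc(Cl)cc2C(CNC(=O)c2ccccc2F)(C(F)(F)F)O1` has not been measured. Relative to compound 3 the change is 2-fluorophenyl in place of 3-fluorophenyl on a carbonyl carbon. Going by the values given here, no measured step bears on this change: the step from compound 1 to compound 2 concerns methyl in place of hydrogen on a saturated chain carbon, a different part of the structure, and no pair in the set shifts a fluorine from one position of an aromatic ring to another. With nothing to anchor a direction, the expectation for compound 4 is a number close to that of compound 3, a step of about a 1.1-fold higher number from compound 3 to compound 4 (0.06 log units; within the scatter), which could fall on either side within the scatter. The estimate for compound 4 in this assay is therefore 300 nM, with a range from 100 nM to 900 nM.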

Compound 4, half-maximal inhibitory concentration: 539 nM
Estimate against measurement, compound 4: 1.8-fold (0.25 log units) below; low and high end bracket the measured number.
By their numbers in this assay, from the lowest: compound 3; then compound 4; then compound 1; then compound 2.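

In this assay, 2-fluorophenyl in place of 3-fluorophenyl on a carbonyl carbon gives a 2.1-fold higher number from compound 3 to compound 4 (0.31 log units; beyond the scatter), a modest step but one beyond the scatter, so this position responds to where the fluorine sits on the ring. The earlier step, a 2.2-fold higher number from compound 1 to compound 2 (0.35 log units; beyond the scatter), lies in a different part of the structure and adds a methyl, whereas compound 3 and compound 4 have the same atoms joined differently, with the counts under comparison unchanged. Nothing measured here accounts for this difference between the two fluorophenyl groups.

Open, as far as these compounds go, is how a plain phenyl group or a pyridyl group on this carbonyl carbon would compare with compound 3 and compound 4, and therefore whether the fluorine is needed at all for numbers in this range. Also open, from the compounds shown here alone, is whether the same change would give a step of similar direction and size in the setting of compound 1 and compound 2, which differ from compound 3 in more than one place and so cannot be compared with it directly.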